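The source may hold more compounds than are shown below. What is called first, only, known or untested is meant among the compounds shown, and "the series" means these compounds.

Compound 1 `O=C(Nc1ccc(S(=O)(=O)Nc2ccccc2)cc1)c1cc(F)c(Cl)cc1F`: 141 nM
Compound 2 `O=C(Nc1ccc(S(=O)(=O)NCc2ccccc2)cc1)c1ccc(Cl)cc1Cl`: > 100000 nM
Compound 3 `COc1ccc(NS(=O)(=O)c2ccc(NC(=O)c3ccc(Cl)cc3Cl)cc2)cc1`: > 100000 nM

Going by the values given here, in a functional assay on HEK293 cells for agonist activity at probable G-protein coupled receptor 27 (Homo sapiens), read by a luciferase reporter and beta-arrestin recruitment, with a stated time of 10 min (on this read-out lower numbers stand for an effect already at smaller amounts and higher numbers for an effect only at larger amounts of compound), compound 1 gives 141 nM, the only actual number among the three values. For compound 2 the assay reports only a limit, > 100000 nM. For compound 3 it likewise reports only a limit, > 100000 nM. The step from compound 2 to compound 3 (a step that the two limits leave unreadable from compound 2 to compound 3) cannot be sized because both values sit at the limit of > 100000 nM in this assay, at which 2 of the 3 values shown sit. Compound 4 `O=C(Nc1ccc(S(=O)(=O)Nc2ccccc2)cc1)c1ccc(Cl)nc1F` differs from compound 1 by 6-chloro-2-fluoropyridin-3-yl in place of 4-chloro-2,5-difluorophenyl on a carbonyl carbon. No measured step touches this part of the molecule: the one step shown alters the group on the sulfonamide nitrogen and is itself unreadable, and compounds 2 and 3 differ from compound 1 in more than one place at once. The measured data therefore give no direction for the change at the carbonyl carbon, and in this assay the step from compound 1 to compound 4 is expected to be modest, a 2.1-fold higher number from compound 1 to compound 4 (0.33 log units; beyond the scatter), with wide uncertainty on either side. Compound 4 is estimated to give about 300 nM, expected to fall between 50 nM and 3000 nM.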

Compound 4, half-maximal effective concentration: 2290 nM
The estimate for compound 4 lay 7.6-fold (0.88 log units) below the measured number; the measured number falls inside the stated range.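

In this assay, going by these compounds alone, the change on the carbonyl carbon is the first readable step at this place, and it is large: 6-chloro-2-fluoropyridin-3-yl in place of 4-chloro-2,5-difluorophenyl gives a 16-fold higher number from compound 1 to compound 4 (1.21 log units; beyond the scatter). The entering ring carries 1 hetero atom and 1 hydrogen-bond acceptor that the leaving ring lacks, and 1 fluorine where the leaving ring carries 2, so this single exchange alters several counted features at once. Nothing measured here accounts for the size of this step.

The compounds shown leave open which of these differences carries the step, and whether a ring with the same hetero atom could read differently with other groups on it. On these data alone, how a nitrile or a methoxy group in place of the chlorine would read in this assay also stays open.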